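Aryl group exchange at the amine of a shared core

The compounds below may be only part of what the source reports. "The series", "measured", "known", "first", "only" and "open" are said of these compounds alone.

The measured compounds, all tested in a functional assay on PC-3 cells (Homo sapiens) for cytotoxicity, read by MTT assay, with a stated time of 72 h; on this read-out higher numbers stand for weaker inhibition and lower numbers for stronger inhibition:
Compound 1 `CCCCCCCCCCCCCCNc1nc(SCc2ccc(C(F)(F)F)cc2)nc2ccccc12` gives a value that is only a limit of the assay, > 50000 nM.
Compound 2 `CCOc1ccccc1Nc1nc(SCc2ccc(C(F)(F)F)cc2)nc2ccccc12` gives 26200 nM.
Compound 3 `Cc1ccccc1Nc1nc(SCc2ccc(C(F)(F)F)cc2)nc2ccccc12` gives 36900 nM.

Among the three, compound 2 holds the lowest of the two numbers; compound 3 sits within the usual scatter of it, and the result for compound 1 is a limit rather than a number (the limit of > 50000 nM in this assay, at which 1 of the 3 values shown sits). Compound 4 `Cc1ccc(Nc2nc(SCc3ccc(C(F)(F)F)cc3)nc3ccccc23)cc1` differs from compound 2 by 4-methylphenyl in place of 2-ethoxyphenyl on a nitrogen on an aromatic ring. Going by the values given here, the only measured step touching this position is a 1.4-fold higher number from compound 2 to compound 3 (0.15 log units; within the scatter), a change within the scatter. Since that step did not move the number beyond the scatter, a change of the same kind on the same nitrogen is expected to leave compound 4 close to compound 2, with no step beyond the scatter in either direction; the expected step is a 1.3-fold higher number from compound 2 to compound 4 (0.10 log units; within the scatter). Compound 4 is therefore estimated at 33000 nM, with a range from 15000 nM to 75000 nM.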

Compound 4, half-maximal inhibitory concentration: 21100 nM
Estimate against measurement, compound 4: 1.6-fold (0.19 log units) above, within the range that was stated.
By their numbers in this assay, from the lowest: compounds 4, 2 and 3 (each within the scatter of the next). At a limit, above all of these: compound 1.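

In this assay, exchanging the aryl group on this nitrogen gives a 1.2-fold lower number from compound 2 to compound 4 (0.09 log units; within the scatter), and the exchange of 2-methylphenyl for 4-methylphenyl gives a 1.7-fold lower number from compound 3 to compound 4 (0.24 log units; within the scatter). Compound 4 thus adds a second kind of change at this position, in which the methyl group sits elsewhere on the phenyl ring, and neither new step leaves the scatter, so the three aryl groups cannot be told apart on this read-out. Nothing in the data shown bears on why these steps stay so small.

Compound 1 gives > 50000 nM, which is a limit of the assay, so the steps to it cannot be read. On these data alone, whether a phenyl ring carrying an amine or a carboxylic acid on this nitrogen would give a step beyond the scatter remains open.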